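The source may hold more compounds than are shown below. What is called first, only, known or untested is meant among the compounds shown, and "the series" means these compounds.

Measured so far in a functional assay on KB cells (Homo sapiens) for inhibition; on this read-out higher numbers stand for weaker inhibition and lower numbers for stronger inhibition:
- compound 1, `CCOC[C@H]1O[C@@H](n2c(Cl)nc3cc(Cl)c(Cl)cc32)[C@H](OC(C)=O)[C@@H]1OC(C)=O`: 60000 nM
- compound 2, `CCCCOC[C@H]1O[C@@H](n2c(Cl)nc3cc(Cl)c(Cl)cc32)[C@H](OC(C)=O)[C@@H]1OC(C)=O`: here the assay returned only a limit, > 100000 nM
- compound 3, `CCOC[C@H]1OC(n2c(Cl)nc3cc(Cl)c(Cl)cc32)[C@H](O)[C@@H]1O`: 80000 nM

Compound 1 and compound 2 share one core and differ in a single place: ethyl in place of hydrogen on a saturated chain carbon, two bonds along the chain from an oxygen on a saturated carbon. That change brought an at least 1.6-fold higher number from compound 1 to compound 2 (0.22 log units; that floor lies within the scatter), a step whose floor lies inside the usual scatter of repeated runs, so it shows no more than that compound 2 is not the stronger of the pair; the result for compound 2 is a limit of the assay, not a number.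

Compound 3 carries a different core, and how its core differs from that of compound 1 is not broken down here. In this assay compound 3 gives a number that sits within the scatter of compound 1, so the two read as alike.

Compound 4, `CCCCOC[C@H]1OC(n2c(Cl)nc3cc(Cl)c(Cl)cc32)[C@H](O)[C@@H]1O`, has not been measured. It stands to compound 3 as compound 2 stands to compound 1: the same change, (ethyl in place of hydrogen on a saturated chain carbon, two bonds along the chain from an oxygen on a saturated carbon), at the same place. Within the data shown here, the only guide to what it does is the one step already seen, which points to the number staying put or rising. For compound 4, resting on an at least 1.6-fold higher number from compound 1 to compound 2 (0.22 log units; that floor lies within the scatter) alone, the expected step is a 1.6-fold higher number from compound 3 to compound 4 (0.21 log units; within the scatter). Compound 4 is therefore estimated at 130000 nM, with a likely range from 60000 nM to 300000 nM, and a fair chance that the assay again reports only a limit.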

Compound 4, half-maximal inhibitory concentration: 60000 nM
For compound 4 the middle estimate is 2.2-fold (0.34 log units) above the measured one; the measured number falls inside the stated range.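

On the second core, going from ethoxy to butoxy gives a 1.3-fold lower number from compound 3 to compound 4 (0.12 log units; within the scatter) in this assay, so the two compounds read as alike. Neither this step nor the earlier one lies beyond the scatter, so this small series gives no sign that adding the ethyl has a clear effect on either core, and it also cannot show that the change acts in the same way on both: the same change on two cores in this assay, an at least 1.6-fold higher number (0.22 log units; that floor lies within the scatter) from compound 1 to compound 2 and a 1.3-fold lower number (0.12 log units; within the scatter) from compound 3 to compound 4; the limit leaves it open whether they differ The result for compound 2 is a limit and not a number, so the true size of the first step remains unknown, and the comparison stays loose: the limit of > 100000 nM in this assay, at which 1 of the 4 values shown sits.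

The compounds shown leave open whether a longer chain than butoxy, or a chain ending in an amine or a carboxylic acid, would move the number beyond the scatter at this place. They also leave open how the same change from ethoxy to butoxy would behave on any core other than these two.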